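Cyclohexyl for 2-chlorophenyl on the benzylic-type carbon

This account rests on a few compounds, and the source may have more. Where it says the series, first, only, none or still open, it means among the compounds named here.

Working notes on a small cytotoxicity set. Compound 1 `Fc1cccc(F)c1Cn1c(-c2c(F)cccc2F)nc2ccncc21` gives 99000 nM in an ADME assay on MDBK cells (Bos taurus) for cytotoxicity; a higher number here means that more compound is tolerated, a lower number that less compound is tolerated. Compound 2 `Clc1ccccc1Cn1ccc2nc(-c3ccccc3)nc-2c1` reaches only the limit of this assay, > 100000 nM, and not a number. Compound 3 `FC(F)(F)c1ccccc1Cn1ccc2nc(-c3ccccc3)nc-2c1` likewise stops at the limit of this assay, > 100000 nM. Among the measured compounds shown here, the one measured step, a step that the two limits leave unreadable from compound 2 to compound 3, cannot be read because the limit of > 100000 nM in this assay, at which 2 of the 3 values shown sit: both ends sit at the limit, so the size is unknown.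

Compound 4 `c1ccc(-c2nc3ccn(CC4CCCCC4)cc-3n2)cc1` is not yet measured. It differs from compound 2 by cyclohexyl in place of 2-chlorophenyl on a saturated chain carbon bound to an aromatic nitrogen. For the measured compounds named here, no measured step bears on a cyclohexyl group in this place; the only step available is unreadable, so there is no precedent for direction or size. Given that compound 2 itself sits at the limit, > 100000 nM, compound 4 is expected to be tolerated at a similarly high level, with a good chance of another limit rather than a number. Compound 4 is estimated at 100000 nM, in the range 40000 nM to 200000 nM. The expected step is a number no higher from compound 2 to compound 4 (the limit leaves the size open), within the scatter.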

Compound 4, half-maximal cytotoxic concentration: > 100000 nM
Compound 4 was reported as a limit; the forecaster's own chance of this, stated with the estimate: 60%; the middle value sits exactly at the limit.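

In this assay compound 4 gives > 100000 nM, a limit and not a number, so the step from compound 2 to compound 4 cannot be read: the limit of > 100000 nM in this assay, at which 3 of the 4 values shown sit.

The compounds shown leave open whether cyclohexyl or 2-chlorophenyl on a saturated chain carbon bound to an aromatic nitrogen is better tolerated, and where compound 2, compound 3 and compound 4 would give actual numbers.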